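Working notes: adding chloro to compound 3

The compounds below may be only part of what the source reports. "The series", "measured", "known", "first", "only" and "open" are said of these compounds alone.

In a functional assay on HCT-116 cells (Homo sapiens) for antiproliferative activity, read by MTT assay, with a stated time of 48 h; on this read-out higher numbers stand for weaker inhibition and lower numbers for stronger inhibition:
compound 1 (`O=C(/C=C/c1ccc(/C=C/C(=O)c2ccc3ccccc3c2)o1)NO`) : 2220 nM
compound 2 (`O=C(/C=C/c1ccc(/C=C/C(=O)c2cccc(Cl)c2)o1)NO`) : 1510 nM
compound 3 (`O=C(/C=C/c1ccc(/C=C/C(=O)c2ccccc2)o1)NO`) : 2890 nM

Compound 3 at 2890 nM lies within the scatter of both other compounds, so the three cannot be ranked. Compound 4 (`O=C(/C=C/c1ccc(/C=C/C(=O)c2ccc(Cl)cc2)o1)NO`) has chloro in place of hydrogen on an aromatic carbon of compound 3, para to a large group: chloro in place of hydrogen on an aromatic carbon. Within the data shown here, one measured step bears on this change: a 1.9-fold higher number from compound 2 to compound 3 (0.28 log units; within the scatter). It removes a chloro from another place on the ring and stays within the scatter. No step beyond the scatter is therefore expected in this assay, at most a slightly lower number. The expected step is a 1.4-fold lower number from compound 3 to compound 4 (0.16 log units; within the scatter). Compound 4 is estimated at 2000 nM, with an expected range of 1000 nM to 3500 nM.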

Compound 4, half-maximal inhibitory concentration: 2010 nM
The estimate for compound 4 lay 1.0-fold (0.00 log units) below the measured number; measured number inside the range.
By their numbers in this assay, from the lowest: compounds 2, 4, 1 and 3 (each within the scatter of the next).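

In this assay, chloro in place of hydrogen on the aromatic carbon para to a large group gives a small step (a 1.4-fold lower number from compound 3 to compound 4 (0.16 log units; within the scatter)), and 4-chlorophenyl in place of 3-chlorophenyl gives another (a 1.3-fold higher number from compound 2 to compound 4 (0.12 log units; within the scatter)). On these numbers, neither adding chloro at this place nor moving it from the other ring place separates the compounds. No supporting data explain these steps.

From the compounds shown here alone, whether an amine or a carboxylic acid at this place would give a step beyond the scatter remains open.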